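Nitro for fluoro on the unfluorinated core

The source may hold more compounds than are shown below. What is called first, only, known or untested is meant among the compounds shown, and "the series" means these compounds.

Measured compounds:
compound 1, `O=C(N/N=C/c1ccc(F)cc1)Nc1ccc(Oc2ccnc3[nH]ccc23)c(F)c1`, 2330 nM
compound 2, `O=C(N/N=C/c1ccc([N+](=O)[O-])cc1)Nc1ccc(Oc2ccnc3[nH]ccc23)c(F)c1`, 150 nM
compound 3, `O=C(N/N=C/c1ccc(F)cc1)Nc1ccc(Oc2ccnc3[nH]ccc23)cc1`, 7490 nM

All three values come from a functional assay on PC-3 cells (Homo sapiens) for antiproliferative activity, read by MTT assay, with a stated time of 72 h; a higher number here means a weaker inhibitor, a lower number a stronger inhibitor. Compound 1 gives 2330 nM in this assay. Compound 2 differs from compound 1 by the change (nitro in place of fluoro on an aromatic carbon), and the step is a 16-fold lower number from compound 1 to compound 2 (1.19 log units; beyond the scatter). Compound 3 differs from compound 1 by the change (hydrogen in place of fluoro on an aromatic carbon); the step is a 3.2-fold higher number from compound 1 to compound 3 (0.51 log units; beyond the scatter), so compound 3 holds the highest number of the three measured compounds, and its gap to compound 2 is also beyond the scatter.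

Compound 4, `O=C(N/N=C/c1ccc([N+](=O)[O-])cc1)Nc1ccc(Oc2ccnc3[nH]ccc23)cc1`, is not yet measured in this assay. It differs from compound 3 by nitro in place of fluoro on an aromatic carbon. This is the same change as that made from compound 1 to compound 2, in the same place and with the same surroundings. The only difference between the two pairs is the core, as described by hydrogen in place of fluoro on an aromatic carbon.

For compound 4 a step of about a 15-fold lower number from compound 3 to compound 4 (1.18 log units; beyond the scatter) is expected, comparable to the step measured from compound 1 to compound 2, because that step a 16-fold lower number from compound 1 to compound 2 (1.19 log units; beyond the scatter) is large and the change is the same. As far as these compounds go, whether the core without the fluoro carries the change as fully is unknown from two pairs alone, so the range is kept wide. Compound 4 is therefore estimated at 500 nM in this assay, between 150 nM and 1800 nM.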

Compound 4, half-maximal inhibitory concentration: 28100 nM
Compound 4: the middle estimate sits 56-fold (1.75 log units) below what was measured; measured number outside the range, above it.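

In this assay, going by these compounds alone, nitro in place of fluoro on the core without the second fluoro gives a 3.8-fold higher number from compound 3 to compound 4 (0.57 log units; beyond the scatter), so the step changes direction from one core to the other: the same change on two cores in this assay, a 16-fold lower number (1.19 log units; beyond the scatter) from compound 1 to compound 2 and a 3.8-fold higher number (0.57 log units; beyond the scatter) from compound 3 to compound 4, 58-fold (1.77 log units) apart, beyond the scatter of two such steps Seen from the other side of the same four compounds, hydrogen in place of fluoro on the core gives a 190-fold higher number from compound 2 to compound 4 (2.27 log units; beyond the scatter) with the 4-nitrophenyl group present, a much larger step than with the 4-fluorophenyl group: the same change on two cores in this assay, a 3.2-fold higher number (0.51 log units; beyond the scatter) from compound 1 to compound 3 and a 190-fold higher number (2.27 log units; beyond the scatter) from compound 2 to compound 4, 58-fold (1.77 log units) apart, beyond the scatter of two such steps The gain from the 4-nitrophenyl group on the core of compound 1 therefore cannot be assumed on the core of compound 3, and the two changes do not simply add; these four compounds show that dependence on the core but not its cause, and they give only one pair on each core.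

Open, as far as these compounds go, is whether an amine, a carboxylic acid or a nitrile in place of the fluoro on the outer ring would follow the direction seen on the core of compound 1 or that seen on the core of compound 3. Also open, from the compounds shown here alone, is whether the 4-nitrophenyl group alone behaves this way or whether other groups at the same place also change direction between the two cores.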